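Methoxy on compound 2: working notes

The compounds below may be only part of what the source reports. "The series", "measured", "known", "first", "only" and "open" are said of these compounds alone.

Measured in a functional assay on A549 cells (Homo sapiens) for cytotoxicity, read by MTT assay, with a stated time of 6 days; a higher number here means that more compound is needed for the effect, a lower number that less compound is needed:
- compound 1 `COC(=O)c1c(-c2ccc([N+](=O)[O-])cc2)oc2ccccc2c1=O`: > 25 ug/mL, a limit
- compound 2 `O=C(O)c1c(-c2ccc([N+](=O)[O-])cc2)oc2ccccc2c1=O`: > 25 ug/mL, a limit

Within the data shown here, compound 2 is known only as a limit, as is the one other value: the limit of > 25 ug/mL in this assay, at which 2 of the 2 values shown sit. Compound 3 `COc1ccc2oc(-c3ccc([N+](=O)[O-])cc3)c(C(=O)O)c(=O)c2c1` carries one change, methoxy in place of hydrogen on an aromatic carbon. Among the measured compounds shown here, the only measured step is a step that the two limits leave unreadable from compound 1 to compound 2. It involves a different change and gives no size to carry over. No step beyond the scatter is therefore expected in this assay. The expected step is a step that the limit leaves unreadable from compound 2 to compound 3. Compound 3 is estimated at 35 ug/mL, with an expected range of 15 ug/mL to 80 ug/mL.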

Compound 3, concentration for half-maximal effect: > 25 ug/mL
Compound 3: a limit, no number; the forecaster's own chance of this, stated with the estimate: 75%; the middle value does not contradict the limit.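

No step can be read from compound 2 to compound 3, as both values are limits: the limit of > 25 ug/mL in this assay, at which 3 of the 3 values shown sit.

The compounds shown leave open what size, if any, the change to methoxy has in this assay.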